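Swapping the pyrazine for an acetamidophenyl on the shared core

This account rests on a few compounds, and the source may have more. Where it says the series, first, only, none or still open, it means among the compounds named here.

Compound 1 `Cc1cc(C#N)cc(-c2c(C)nn(-c3nc(-c4ccc(Cl)c(Cl)c4)c(SC(C)C)s3)c2C(=O)O)c1` gives 4800 nM in a functional assay on BJAB cells (Homo sapiens) for antiproliferative activity, with a stated time of 4 days; a higher number here means that more compound is needed for the effect, a lower number that less compound is needed.
Compound 2 `Cc1nn(-c2nc(-c3ccc(Cl)c(Cl)c3)c(SC(C)C)s2)c(C(=O)O)c1-c1cccc(Cl)c1C` gives 5100 nM.
Compound 3 `Cc1nn(-c2nc(-c3ccc(Cl)c(Cl)c3)c(SC(C)C)s2)c(C(=O)O)c1-c1cnccn1` gives 14000 nM.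

Compound 3 has the highest number of the three: the steps of a 2.9-fold higher number from compound 1 to compound 3 (0.46 log units; beyond the scatter) and a 2.7-fold higher number from compound 2 to compound 3 (0.44 log units; beyond the scatter) are both beyond the scatter, whereas a 1.1-fold higher number from compound 1 to compound 2 (0.03 log units; within the scatter) is not. Compound 4 `CC(=O)Nc1ccc(-c2c(C)nn(-c3nc(-c4ccc(Cl)c(Cl)c4)c(SC(C)C)s3)c2C(=O)O)cc1` differs from compound 3 by 4-acetamidophenyl in place of pyrazin-2-yl on an aromatic carbon. The two steps that bear on this change are those in which pyrazin-2-yl entered in place of a carbon-only ring, and both raised the number modestly. Putting a carbon-only ring back in its place is expected to lower the number in this assay by a similar amount. Compound 4 is therefore estimated at 5500 nM, within a range of 2500 nM to 12000 nM. This expected change corresponds to a 2.5-fold lower number from compound 3 to compound 4 (0.41 log units; beyond the scatter).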

Compound 4, half-maximal effective concentration: 139000 nM
For compound 4 the middle estimate is 25-fold (1.40 log units) below the measured one; the whole stated range lies below it.
By their numbers in this assay, from the lowest: compounds 1 and 2 (each within the scatter of the next); then compound 3; then compound 4.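

In this assay a carbon-only ring at this position does not by itself bring the number down: 4-acetamidophenyl in place of pyrazin-2-yl gives a 9.9-fold higher number from compound 3 to compound 4 (1.00 log units; beyond the scatter). Among these compounds, the gap is wider against the other two carbon-only rings (with a 27-fold higher number from compound 2 to compound 4 (1.44 log units; beyond the scatter) and a 29-fold higher number from compound 1 to compound 4 (1.46 log units; beyond the scatter)), so what the ring carries counts for more here than the earlier compounds showed. Nothing measured here accounts for this rise. The compounds shown leave open whether the rise follows the acetamido group itself, as a 4-aminophenyl group could tell, or its place on the ring, as a 3-acetamidophenyl group could tell.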